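A few compounds are considered here, and "the series" means these few. Any claim that something is new, unique, unknown or untested is made for them only; others in the source may bear on it.

Three compounds share one core and differ only in the group on one aromatic ring. Compound 1 `Cc1ccc(N2C(=O)/C(=C/c3ccc(OCc4ccc(C(=O)O)cc4)cc3)SC2=S)cc1` carries a methyl there. In an assay on isolated protein for inhibition of Apoptosis regulator Bcl-2 (Homo sapiens), read by fluorescence polarization (on this read-out higher numbers stand for weaker inhibition and lower numbers for stronger inhibition), compound 1 gives only a limit of the assay, > 10000 nM. Compound 2 `COc1ccc(N2C(=O)/C(=C/c3ccc(OCc4ccc(C(=O)O)cc4)cc3)SC2=S)cc1` carries a methoxy in its place. In this assay compound 2 likewise reaches only a limit, > 10000 nM. Compound 3 `O=C(O)c1ccc(COc2ccc(/C=C3\SC(=S)N(c4ccc(Cl)cc4)C3=O)cc2)cc1` carries a chloro. In this assay compound 3 also stops at a limit, > 10000 nM. Because all three sit at the limit of > 10000 nM in this assay, at which 3 of the 3 values shown sit, the steps between them cannot be sized: a step that the two limits leave unreadable from compound 1 to compound 2, a step that the two limits leave unreadable from compound 1 to compound 3 and a step that the two limits leave unreadable from compound 2 to compound 3 are all unreadable. Compound 3 thus stands where every measured compound stands, at the limit, with no number of its own.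

Compound 4 `O=C(O)c1ccc(COc2ccc(/C=C3\SC(=S)N(c4ccc(Br)cc4)C3=O)cc2)cc1` is the next variation: bromo in place of chloro on an aromatic carbon. The measured steps that bear on this change are the three just named, and each is unreadable; the limit hides any difference between methyl, methoxy and chloro. Among the compounds with values here, nothing among the measured compounds suggests that the limit would be crossed by this exchange. The step in this assay is therefore expected to be a step that the limit leaves unreadable from compound 3 to compound 4, meaning none beyond the scatter. Compound 4 is accordingly expected to give 15000 nM in this assay, between 5000 nM and 50000 nM, most likely reported again only as a limit.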

Compound 4, inhibition constant: 610 nM
The estimate for compound 4 lay 25-fold (1.39 log units) above the measured number; measured number outside the range, below it.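

In this assay this position on the aromatic ring proves able to change the read-out, as the exchange of 4-chlorophenyl for 4-bromophenyl gives an at least 16-fold lower number from compound 3 to compound 4 (1.21 log units; beyond the scatter) within a shared core that otherwise stays the same. Bromo also stands clear of the other two groups, with an at least 16-fold lower number from compound 2 to compound 4 (1.21 log units; beyond the scatter) and with an at least 16-fold lower number from compound 1 to compound 4 (1.21 log units; beyond the scatter) as well, so the exchange of one heavy atom for another at this place is enough to yield a readable number. Bromo is the only group shown that brings a compound off the limit: the limit of > 10000 nM in this assay, at which 3 of the 4 values shown sit.

Going by these compounds, the steps among the methyl, methoxy and chloro compounds still cannot be read, so their order relative to one another remains unknown. On these data alone, whether the drop in the number is particular to bromo or extends to other groups at this place, such as iodo, trifluoromethyl or a nitrile, also remains open.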